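Swapping iodo for tert-butyl on the shared core

The compounds below may be only part of what the source reports. "The series", "measured", "known", "first", "only" and "open" are said of these compounds alone.

In a functional assay on M21 cells (Homo sapiens) for antiproliferative activity, read by sulforhodamine B assay, with a stated time of 48 h (on this read-out higher numbers stand for weaker inhibition and lower numbers for stronger inhibition), compound 1 (`O=C1NCCN1c1ccc(S(=O)(=O)Nc2ccc(F)cc2)cc1`) gives 230 nM and compound 2 (`O=C1NCCN1c1ccc(S(=O)(=O)Nc2ccc(I)cc2)cc1`) gives 260 nM on the same test, so these two values lie within the usual scatter of each other. Compound 3 (`CC(C)(C)c1ccc(NS(=O)(=O)c2ccc(N3CCNC3=O)cc2)cc1`) has not yet been measured. Its change from compound 2 is tert-butyl in place of iodo on an aromatic carbon and the rest of the structure stays the same. Among the compounds with values here, only one measured step bears on this, iodo in place of fluoro on an aromatic carbon, and it amounts to a 1.1-fold higher number from compound 1 to compound 2 (0.05 log units; within the scatter) as the sole guide. From the compounds shown here alone, that is thin evidence, and tert-butyl itself is untested here. The estimated step is a 1.2-fold higher number from compound 2 to compound 3 (0.06 log units; within the scatter) in this assay and no change beyond the scatter is expected. The estimate for compound 3 is 300 nM with an expected range from 100 nM to 900 nM.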

Compound 3, half-maximal inhibitory concentration: > 1000 nM
Compound 3 ended at the assay's limit; the forecaster's own chance of this, stated with the estimate: 3%; middle value at least 3.3-fold (0.52 log units) from the limit.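

Compound 3 reads > 1000 nM in this assay, and this reading is a limit of the assay, not a number: the limit of > 1000 nM in this assay, at which 1 of the 3 values shown sits.

Even so, the steps show that this position does not accept every group equally: tert-butyl in place of iodo gives an at least 3.8-fold higher number from compound 2 to compound 3 (0.58 log units; beyond the scatter), and tert-butyl in place of fluoro gives an at least 4.3-fold higher number from compound 1 to compound 3 (0.63 log units; beyond the scatter), whereas the earlier swap of iodo for fluoro gave only a 1.1-fold higher number from compound 1 to compound 2 (0.05 log units; within the scatter). Within the data shown here, the two halogens alone gave no sign that the group on this aromatic carbon matters, and tert-butyl is the first group here to weaken inhibition beyond the scatter.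

From the compounds shown here alone, it stays open whether this loss belongs to tert-butyl alone or extends to smaller carbon groups, which a methyl or an ethyl group here would test. An amine or a carboxylic acid at this place would show how a group of a different kind behaves.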